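Three Ether Variants at the Limit, and a Bromophenyl Newcomer

The compounds below may be only part of what the source reports. "The series", "measured", "known", "first", "only" and "open" are said of these compounds alone.

Compound 1 `Cc1nn(C)c(Oc2cccc(F)c2)c1/C=N\CCCCCCOc1cc2oc(=O)cc(C)c2cc1Cl` gives in a functional assay on HepG2 cells (Homo sapiens) for antiproliferative activity, read by MTT assay, with a stated time of 72 h (on this read-out higher numbers stand for weaker inhibition and lower numbers for stronger inhibition), a value of > 25000 nM, which is a limit of the assay rather than a number.
Compound 2 `Cc1nn(C)c(Oc2cccc(F)c2F)c1/C=N\CCCCCCOc1cc2oc(=O)cc(C)c2cc1Cl` gives in this assay a value of > 25000 nM, again a limit.
Compound 3 `Cc1nn(C)c(Oc2ccc(F)c(F)c2)c1/C=N\CCCCCCOc1cc2oc(=O)cc(C)c2cc1Cl` gives in this assay a value of > 25000 nM, once more a limit.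

Compound 3 therefore stands where every measured compound stands: at the limit, as described by the limit of > 25000 nM in this assay, at which 3 of the 3 values shown sit. The three steps among the measured compounds cannot be sized. The step that the two limits leave unreadable from compound 1 to compound 2 and the step that the two limits leave unreadable from compound 1 to compound 3 each add one fluoro on an aromatic carbon, and the step that the two limits leave unreadable from compound 2 to compound 3 moves from 2,3-difluorophenyl to 3,4-difluorophenyl on the aryl ether oxygen; none of them can be read, since both ends sit at the limit.

Compound 4 `Cc1nn(C)c(Oc2ccccc2Br)c1/C=N\CCCCCCOc1cc2oc(=O)cc(C)c2cc1Cl` carries a different ether group. The change is 2-bromophenyl in place of 3,4-difluorophenyl on an oxygen on an aromatic ring. All measured steps that touch this ether group are unreadable, so they give no direction and no size to expect in this assay; the closest guess is that the change stays within the scatter, with compound 4 again reported only as a limit. Compound 4 is accordingly expected to give about 30000 nM, in a range from 8000 nM to 100000 nM. That expectation means a step that the limit leaves unreadable from compound 3 to compound 4.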

Compound 4, half-maximal inhibitory concentration: 24200 nM
Compound 4: the middle estimate sits 1.2-fold (0.09 log units) above what was measured; the measured number falls inside the stated range.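

At this position, on an oxygen on an aromatic ring, the 2-bromophenyl group of compound 4 is the first to give a real number in this assay, while the three fluorophenyl ethers stay at the limit: the limit of > 25000 nM in this assay, at which 3 of the 4 values shown sit.

Set against those ethers, the change gives an at least 1.0-fold lower number from compound 3 to compound 4 (0.01 log units; that floor lies within the scatter), an at least 1.0-fold lower number from compound 2 to compound 4 (0.01 log units; that floor lies within the scatter) and an at least 1.0-fold lower number from compound 1 to compound 4 (0.01 log units; that floor lies within the scatter). Each of these is only a floor and each lies within the scatter, so the result shows that this position can yield a readable number, not that compound 4 is a better inhibitor than the three before it.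

The compounds shown leave open whether the number comes from the bromine itself or from where it sits on the ring, which a 2-chlorophenyl or a 4-bromophenyl ether on the same oxygen would help to separate. They also leave open how far the ether position matters compared with the rest of the molecule, for instance if a shorter or longer chain replaced the one linking the two halves, or if an amine were placed on the phenyl ring.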